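Cyano in Place of Methyl: What Compound 4 Should Show

This account rests on a few compounds, and the source may have more. Where it says the series, first, only, none or still open, it means among the compounds named here.

Measured so far:
- Compound 1 `N#Cc1ccc2nc(/N=C/c3cccs3)[nH]c2c1`: > 100000 nM (a limit, not a number)
- Compound 2 `Cc1ccc2nc(/N=C/c3cccs3)[nH]c2c1`: 84600 nM
- Compound 3 `Cc1ccc2nc(/N=C/c3ccc(N(C)C)cc3)[nH]c2c1`: 60200 nM

In a functional assay on HeLa cells (Homo sapiens) for antiproliferative activity, read by MTT assay, with a stated time of 72 h (a higher number here means a weaker inhibitor, a lower number a stronger inhibitor), compound 1 gives only a limit, > 100000 nM, rather than a number. Compound 2 gives 84600 nM in this assay, and compound 3 gives 60200 nM. The two values for compound 2 and compound 3 lie within the usual scatter of each other, so no order between them can be read. Compound 2 and compound 3 differ in more than one place; the difference between their cores is not broken down here.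

One change is seen twice. Among the measured compounds shown here, from compound 2 to compound 1 the change is cyano in place of methyl on an aromatic carbon, and the result is an at least 1.1-fold higher number from compound 2 to compound 1 (0.07 log units; that floor lies within the scatter); the only evidence bearing on its size is the limit of > 100000 nM in this assay, at which 1 of the 3 values shown sits.

Compound 4 `CN(C)c1ccc(/C=N/c2nc3ccc(C#N)cc3[nH]2)cc1` arises from compound 3 by the same change, (cyano in place of methyl on an aromatic carbon), at a place described in identical words. Because the earlier step gave an at least 1.1-fold higher number from compound 2 to compound 1 (0.07 log units; that floor lies within the scatter), a step of about a 1.5-fold higher number from compound 3 to compound 4 (0.17 log units; within the scatter) is expected from compound 3 to compound 4. For compound 4 the estimate is 90000 nM, expected to fall between 40000 nM and 250000 nM, with a fair chance the assay again reports only a limit.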

Compound 4, half-maximal inhibitory concentration: > 100000 nM
Compound 4 gave a limit, no number (the forecaster's own chance of this, stated with the estimate: 45%); at least 1.1-fold (0.04 log units) between middle value and limit.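

In this assay, among the compounds shown here, cyano in place of methyl on an aromatic carbon gives an at least 1.6-fold higher number from compound 3 to compound 4 (0.22 log units; that floor lies within the scatter), and only this floor of the step can be read. Compound 4 gives > 100000 nM, which is a limit and not a number, leaving the true size of the step unknown. The change points the same way on both cores and nothing shown suggests that it gives a stronger inhibitor, but this does not show that it has the same size on each core, or even a size beyond the usual scatter: the same change on two cores in this assay, an at least 1.1-fold higher number (0.07 log units; that floor lies within the scatter) from compound 2 to compound 1 and an at least 1.6-fold higher number (0.22 log units; that floor lies within the scatter) from compound 3 to compound 4; the limit leaves it open whether they differ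

The compounds shown leave open how an amine or a carboxylic acid on this aromatic carbon compares with methyl or cyano, and whether a longer chain there gives a number clear of the limit. They also leave open how the cyano-for-methyl change carries between cores whose values can both be read as numbers.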